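A few compounds are considered here, and "the series" means these few. Any claim that something is new, unique, unknown or untested is made for them only; others in the source may bear on it.

The three measured compounds share one core. Compound 1 `Cc1ccccc1-c1nc(CN2CCC(C(=O)NCCCN3CCC(C(C)C)CC3)CC2)c(C)o1` carries a 4-isopropylpiperidin-1-yl group, compound 3 `Cc1ccccc1-c1nc(CN2CCC(C(=O)NCCCCN3C[C@H](C)C[C@H](C)C3)CC2)c(C)o1` carries a (3,5-dimethylpiperidin-1-yl)methyl group in its place, and compound 2 `Cc1oc(-c2c(F)cccc2F)nc1CN1CCC(C(=O)NCCCN2C[C@H](C)C[C@H](C)C2)CC1` carries a 2,6-difluorophenyl group. In a physicochemical assay for solubility, in phosphate buffer, measured as kinetic solubility, at pH 7.4 (on this read-out lower numbers stand for lower solubility and higher numbers for higher solubility), compound 1 gives > 71 ug/mL, which is a limit of the assay rather than a number. Compound 3 gives > 71 ug/mL, also a limit. Compound 2 gives > 72 ug/mL, again a limit. Two of the three values sit at the limit of > 71 ug/mL in this assay, at which 2 of the 3 values shown sit, and one at the limit of > 72 ug/mL in this assay, at which 1 of the 3 values shown sits, so compound 2 stands where every measured compound stands: at the limit, with no number. Among the compounds with values here, the one measured step that the two limits leave unreadable from compound 1 to compound 3 has a limit at each end and so gives no size. Within the data shown here, compound 4 `COc1ccc(-c2nc(CN3CCC(C(=O)NCCCN4C[C@H](C)C[C@H](C)C4)CC3)c(C)o2)cc1OC` differs from compound 2 in 3,4-dimethoxyphenyl in place of 2,6-difluorophenyl on an aromatic carbon, a change that no measured step touches. Among the measured compounds shown here, no step therefore supports an expectation either way. Compound 4 is expected to give 72 ug/mL, between 30 ug/mL and 150 ug/mL. The step of a number no higher from compound 2 to compound 4 (the limit leaves the size open) is expected to be small, most likely again reported only as a limit.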

Compound 4, solubility: > 76 ug/mL
Compound 4: a limit, no number (the forecaster's own chance of this, stated with the estimate: 70%); middle value at least 1.0-fold (0.02 log units) away from the limit.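

Within the data shown here, compound 2 and compound 4 both stand at a limit in this assay, not at a number, so no step between them can be read. The compounds shown leave open what number any of them would give, and whether 3,4-dimethoxyphenyl in place of 2,6-difluorophenyl changes the read-out at all.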